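Adding a methoxy group to a weakly active cooling-agent scaffold

The compounds below may be only part of what the source reports. "The series", "measured", "known", "first", "only" and "open" are said of these compounds alone.

Compound 1, `CCN(Cc1cccs1)C(=O)COc1ccccc1`, is the least potent of three related amides in an assay on HEK293 cells for agonist activity at transient receptor potential cation channel subfamily M member 8 (Homo sapiens), read by fluorescence and calcium flux, with a stated time of 15 min (a lower number here means that less compound is needed, a higher number that more compound is needed for the effect), where compound 1 gives 1400 nM. Its nearest neighbour, compound 3, `CCN(Cc1cccs1)C(=O)COc1cccc(C)c1`, carries a methyl on the aromatic ring and gives 97 nM; compound 2, `CCN(Cc1cccs1)C(=O)COc1ccc2c(c1)CCC2`, in which the ring is fused to a further carbocycle, gives 0.8 nM. Compound 4, `CCN(Cc1cccs1)C(=O)COc1ccc(OC)cc1`, differs from compound 1 by methoxy in place of hydrogen on an aromatic carbon.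

For the measured compounds named here, only one directly comparable step is known: a 14-fold lower number from compound 1 to compound 3 (1.16 log units; beyond the scatter). Together with the far lower number of compound 2, this suggests that decorating the bare phenyl ring of compound 1 tends to lower the concentration needed, though both examples place the new group at a different position from the methoxy of compound 4, and no methoxy analogue has been measured. A cautious expectation is therefore a moderate improvement, a 3.5-fold lower number from compound 1 to compound 4 (0.54 log units; beyond the scatter), with wide uncertainty. Compound 4 is estimated at 400 nM, plausibly between 80 nM and 2000 nM.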

Compound 4, half-maximal effective concentration: 120 nM
Compound 4: middle estimate off by 3.3-fold (0.52 log units), on the high side; the measured number falls inside the stated range.
By their numbers in this assay, from the lowest: compound 2; then compounds 3 and 4 (each within the scatter of the next); then compound 1.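

In this assay, methoxy in place of hydrogen on an aromatic carbon, para to a large group, gives a 12-fold lower number from compound 1 to compound 4 (1.07 log units; beyond the scatter), so a large drop in the number needed is possible from a change at this position of the ring. For the compounds shown here, until now, the only single-change step on this ring was a methyl at a different position, a 14-fold lower number from compound 1 to compound 3 (1.16 log units; beyond the scatter); both steps are large, so the drop in compound 1 is not tied to one group or one position. No measurement at hand explains this effect.

Going by these compounds, it remains open whether an amine, a hydroxy group or a longer chain such as ethoxy at this position would lower the number as well. On these data alone, it is also open whether adding a methoxy to compound 3 would lower the number further.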